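Shortening the Chain: An Estimate of Cytotoxicity

This account rests on a few compounds, and the source may have more. Where it says the series, first, only, none or still open, it means among the compounds named here.

Measured compounds:
compound 1, `COCCOCCOCCOCC(=O)Oc1c(C(C)C)cccc1C(C)C`, 650000 nM
compound 2, `COCCOCCOCCOCCOCC(=O)Oc1c(C(C)C)cccc1C(C)C`, 440000 nM
compound 3, `COCCOCCOCCOCCOCCOCCOCCOC(=O)Oc1c(C(C)C)cccc1C(C)C`, 110000 nM

All three compounds were tested in an ADME assay on L929 cells (Mus musculus) for cytotoxicity, read by MTT assay, with a stated time of 24 h; on this read-out higher numbers stand for an effect only at larger amounts of compound and lower numbers for an effect already at smaller amounts. Compound 1 gives 650000 nM, compound 2 gives 440000 nM, and compound 3 gives 110000 nM. Compounds 1 and 2 share a core and differ only in the length of their chain: hydrogen in place of methoxymethyl on a saturated chain carbon bound to an oxygen on a saturated carbon. This step, a 1.5-fold higher number from compound 2 to compound 1 (0.17 log units; within the scatter), is small enough to count as no real change. Compound 3 has the lowest number of the three, beyond the scatter from both others, but the difference between its core and that of compound 2 is not broken down here, so the two groups of compounds cannot be compared piece by piece.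

Compound 4, `COCCOCCOCCOCCOCCOCCOC(=O)Oc1c(C(C)C)cccc1C(C)C`, has not yet been measured in this assay. It relates to compound 3 exactly as compound 1 relates to compound 2: hydrogen in place of methoxymethyl on a saturated chain carbon bound to an oxygen on a saturated carbon. The place of the change is the same in both pairs, so this is the same change made on a different core. Among the compounds with values here, the one measured example of this change, a 1.5-fold higher number from compound 2 to compound 1 (0.17 log units; within the scatter), stayed within the scatter; the expectation for compound 4 rests on that step being repeated from compound 3. Compound 4 is therefore expected to give roughly a 1.4-fold higher number from compound 3 to compound 4 (0.13 log units; within the scatter), landing at about 150000 nM in this assay, with a plausible range from 70000 nM to 320000 nM.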

Compound 4, half-maximal effective concentration: 510000 nM
Beside the measured number, compound 4's estimate is 3.4-fold (0.53 log units) below it, outside the stated range (above it).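

In this assay, putting hydrogen in place of methoxymethyl on a saturated chain carbon bound to an oxygen on a saturated carbon gives a 4.6-fold higher number from compound 3 to compound 4 (0.67 log units; beyond the scatter), so on this core the shorter chain shows the effect only at a clearly larger amount of compound. Set beside the earlier example, the same change does not carry over with the same size from one core to the other: the same change on two cores in this assay, a 1.5-fold higher number (0.17 log units; within the scatter) from compound 2 to compound 1 and a 4.6-fold higher number (0.67 log units; beyond the scatter) from compound 3 to compound 4, 3.1-fold (0.50 log units) apart, beyond the scatter of two such steps

The earlier step can be read as no real change, while the new one cannot, so the size of this step on one core is a poor guide to its size on the other; two pairs show that the core matters here, but not why, and they do not show what the change would do on any further core.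

Every chain shown ends in a methoxy group, so it remains open whether a chain ending in a hydroxyl group, an amine or a carboxylic acid would behave in the same way. From the compounds shown here alone, it also remains open whether a chain longer than that of compound 3 would continue the trend seen from compound 4 to compound 3 on its core, or whether the number would level off.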